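Trifluoromethoxy for methoxy on a cyclohexenone benzylidene series

A few compounds are considered here, and "the series" means these few. Any claim that something is new, unique, unknown or untested is made for them only; others in the source may bear on it.

Compound 1 `COc1ccc(/C=C2\CCC=CC2=O)cc1` and compound 2 `COc1cccc(/C=C2\CCC=CC2=O)c1` share the same atoms joined differently; the difference between the two cores is not broken down here. In a functional assay on MDA-MB-231 cells (Homo sapiens) for antiproliferative activity, read by sulforhodamine B assay, with a stated time of 72 h (a higher number here means a weaker inhibitor, a lower number a stronger inhibitor), compound 1 gives 1620 nM and compound 2 gives 1060 nM, a gap within the scatter. Compound 3 `O=C1C=CCC/C1=C\c1ccc(OC(F)(F)F)cc1` carries the change trifluoromethyl in place of methyl on an oxygen on an aromatic ring relative to compound 1, and in this assay compound 3 gives 590 nM, a step of a 2.7-fold lower number from compound 1 to compound 3 (0.44 log units; beyond the scatter). Compound 4 `O=C1C=CCC/C1=C\c1cccc(OC(F)(F)F)c1` carries the same change trifluoromethyl in place of methyl on an oxygen on an aromatic ring relative to compound 2. Compound 4 is expected to show a step of about a 2.7-fold lower number from compound 2 to compound 4 (0.42 log units; beyond the scatter) in this assay, because the same change gave a 2.7-fold lower number from compound 1 to compound 3 (0.44 log units; beyond the scatter) from compound 1 to compound 3. On that basis compound 4 is estimated at 400 nM in this assay, likely between 200 nM and 800 nM.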

Compound 4, half-maximal inhibitory concentration: 820 nM
Compound 4: middle estimate off by 2.1-fold (0.31 log units), on the low side; the measured number lies above the stated range.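

Methoxy to trifluoromethoxy on the core of compound 2 reads as a 1.3-fold lower number from compound 2 to compound 4 (0.11 log units; within the scatter) in this assay, so no gain can be claimed on this core taken alone. The two steps cannot be told apart, so unequal transfer between the cores is not shown: the same change on two cores in this assay, a 2.7-fold lower number (0.44 log units; beyond the scatter) from compound 1 to compound 3 and a 1.3-fold lower number (0.11 log units; within the scatter) from compound 2 to compound 4, 2.1-fold (0.33 log units) apart, within the scatter of two such steps Nor is equal transfer shown, since there is only one pair per core and one step lies beyond the scatter while the other lies within it.

Still open, as far as these compounds go, is whether an ethyl or difluoromethyl group on the oxygen would follow either step. Also open, from the compounds shown here alone, is how an amine or a nitrile in place of the whole ether would compare on these cores.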